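This account rests on a few compounds, and the source may have more. Where it says the series, first, only, none or still open, it means among the compounds named here.

Measured compounds:
compound 1 `CC(C)(C)Cc1c(-c2cccnc2)sc(N)c1C(=O)c1ccc(Cl)cc1` with 1%
compound 2 `CC(C)(C)Cc1c(-c2ccccc2)sc(N)c1C(=O)c1cccc(Cl)c1` with 2%

In an assay on CHO cells for displacement of a labelled ligand from adenosine receptor A1 (Homo sapiens), read by scintillation counting, tested at 10 uM (on this read-out higher numbers stand for more inhibition at the one concentration tested (going by the name of the read-out) and lower numbers for less inhibition), compound 1 gives 1%. Compound 2 gives 2% in this assay, and the two numbers lie within the usual scatter of each other, so nothing separates compound 1 from compound 2 on this read-out; both show essentially no displacement at the single concentration tested. The unmeasured compound 3 `COc1ccc(-c2sc(N)c(C(=O)c3ccc(Cl)cc3)c2CC(C)(C)C)cc1` keeps the shared core of compound 1 and differs in one place: 4-methoxyphenyl in place of pyridin-3-yl on an aromatic carbon. For the measured compounds named here, no step between measured compounds is available to calibrate such an exchange of one ring for another at this position. With both measured compounds near the bottom of the scale, the step from compound 1 to compound 3 is expected to be small, none beyond the scatter, and compound 3 is expected to give 5% in this assay, within a range from -5% to 20%; this means an expected change a number 4 percentage points higher from compound 1 to compound 3 (within the scatter).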

Compound 3, a percentage reported as inhibition, at one concentration (the size of the read-out at that concentration, not a potency): 1%
Beside the measured number, compound 3's estimate is 4 percentage points above it, within the range that was stated.
By their numbers in this assay, from the lowest: compounds 1, 3 and 2 (each within the scatter of the next).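

In this assay, replacing pyridin-3-yl with 4-methoxyphenyl on the aromatic carbon next to the ring sulfur gives no change at the digits printed from compound 1 to compound 3 (within the scatter). This is the first step shown at this position, and it shows that exchanging a ring with one hetero atom for a ring of carbon only that bears a methoxy group does not lift compound 3 off the bottom of the scale. No supporting data bear on why the exchange leaves the read-out where it is.

The compounds shown leave open whether any group at this position can produce measurable displacement, such as a carboxylic acid or a morpholine ring. They also leave open whether changing another part of the shared core, such as replacing the neopentyl group with an ethyl chain, would do so.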